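From benzyl(methyl)amino to piperidin-1-yl: a cytotoxicity estimate

The source may report more compounds than this note shows. Statements on the series, on what has been measured and on what is new or still open speak of the compounds shown alone.

Compound 1 `CCCCn1cc(C(=O)NCc2ccccc2)c(=O)c2cc(F)c(N3CCCCC3)cc21` gives 47800 nM
Compound 2 `CCCCn1cc(C(=O)O)c(=O)c2cc(F)c(N(C)Cc3ccccc3)cc21` gives 43200 nM

These numbers come from an ADME assay on J774.1 cells (Mus musculus) for cytotoxicity, read by resazurin assay, with a stated time of 48 h (on this read-out lower numbers stand for stronger inhibition and higher numbers for weaker inhibition), and the two values lie within the usual scatter of each other, so compound 2 stands level with compound 1. Compound 3 `CCCCn1cc(C(=O)O)c(=O)c2cc(F)c(N3CCCCC3)cc21` carries piperidin-1-yl in place of benzyl(methyl)amino on an aromatic carbon and keeps everything else from compound 2. Going by the values given here, no measured pair shows this change alone, so the evidence is thin. A modest move toward weaker inhibition is expected, an estimated 1.7-fold higher number from compound 2 to compound 3 (0.24 log units; within the scatter) in this assay on this uncertain basis. Compound 3 is expected near 75000 nM within an estimated range of 35000 nM to 160000 nM in this test.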

Compound 3, half-maximal inhibitory concentration: 93000 nM
Beside the measured number, compound 3's estimate is 1.2-fold (0.09 log units) below it, within the range that was stated.
By their numbers in this assay, from the lowest: compounds 2, 1 and 3 (each within the scatter of the next, the first and the last beyond it).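

In this assay, piperidin-1-yl in place of benzyl(methyl)amino gives a 2.2-fold higher number from compound 2 to compound 3 (0.33 log units; beyond the scatter), the first single-place comparison showing that the group on this aromatic carbon can shift the number, though only modestly. Hydroxy in place of benzylamino on the carbonyl carbon gives a 1.9-fold higher number from compound 1 to compound 3 (0.29 log units; within the scatter), which leaves those two compounds level. Nothing available here explains the piperidin-1-yl result. Still open, as far as these compounds go, is how a morpholin-4-yl or pyrrolidin-1-yl group on the same aromatic carbon would read in this assay.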